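Swapping nitro for chloro on a naphthol amide series

The compounds below may be only part of what the source reports. "The series", "measured", "known", "first", "only" and "open" are said of these compounds alone.

Compound 1: `O=C(Nc1cc(Sc2ncn[nH]2)c(O)c2ccccc12)c1cccc([N+](=O)[O-])c1`, 26900 nM
Compound 2: `O=C(Nc1cc(Sc2ncnc3nc[nH]c23)c(O)c2ccccc12)c1ccc(Cl)cc1`, 66400 nM

Both compounds were tested in a functional assay on PC-3 cells (Homo sapiens) for antiproliferative activity, read by MTT assay, with a stated time of 48 h; on this read-out lower numbers stand for stronger inhibition and higher numbers for weaker inhibition. Compound 1 gives 26900 nM, and compound 2 gives 66400 nM. Compound 1 therefore has the lower number of the two, and the gap to compound 2 lies beyond the usual scatter. Compound 2 differs from compound 1 in more than one place, so its number says little about any single change.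

Compound 3 is `O=C(Nc1cc(Sc2ncn[nH]2)c(O)c2ccccc12)c1cccc(Cl)c1`. It keeps the core of compound 1 and differs from it in one place: chloro in place of nitro on an aromatic carbon. Going by the values given here, no measured pair in this set isolates that change, so there is nothing to lean on besides the number for compound 1 itself. The step from compound 1 to compound 3 is expected to be small, as a 1.1-fold higher number from compound 1 to compound 3 (0.05 log units; within the scatter), and quite possibly within the scatter in either direction. Compound 3 is therefore estimated to give about 30000 nM in this assay, with a range from 10000 nM to 90000 nM.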

Compound 3, half-maximal inhibitory concentration: 85600 nM
The estimate for compound 3 lay 2.9-fold (0.46 log units) below the measured number; the measured number falls inside the stated range.
By their numbers in this assay, from the lowest: compound 1; then compounds 2 and 3 (each within the scatter of the next).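

Going by these compounds alone, until this result, no measured pair showed whether changing the group on this aromatic ring alters the read-out at all. In this assay the change from 3-nitrophenyl to 3-chlorophenyl gives a 3.2-fold higher number from compound 1 to compound 3 (0.50 log units; beyond the scatter) and, although modest, this step lies beyond the usual scatter, so this position is not indifferent to the group it carries, and the nitro group of compound 1 goes with the stronger inhibition of this pair. No measured property of these compounds bears on the step, so the data show that the number changes but offer no explanation for it.

The compounds shown leave open how other groups at this position, such as an amine, a carboxylic acid or a methoxy group, would compare with the nitro group of compound 1 and the chloro group of compound 3. They also leave open whether chloro in place of nitro would give a step of similar size on a different core, as a single pair cannot establish a trend.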